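Methoxy to fluoro on the second phenyl arm

The source may report more compounds than this note shows. Statements on the series, on what has been measured and on what is new or still open speak of the compounds shown alone.

Three compounds share one core and differ only in the phenyl arm. Compound 1 `COc1ccc(-c2cn3ccnc3c(-c3ccc4ncn(C5CCCCC5)c4c3)n2)cc1` carries a 4-methoxyphenyl; in a functional assay on 786-0 cells (Homo sapiens) for inhibition, read by sulforhodamine B assay, with a stated time of 48 h, tested at 10 uM (on this read-out higher numbers stand for more inhibition at the one concentration tested (going by the name of the read-out) and lower numbers for less inhibition), compound 1 gives 83.2%. Compound 2 `Fc1ccc(-c2cn3ccnc3c(-c3ccc4ncn(C5CCCCC5)c4c3)n2)cc1` carries a 4-fluorophenyl, and compound 2 gives 11.2%. Compound 3 `COc1ccccc1-c1cn2ccnc2c(-c2ccc3ncn(C4CCCCC4)c3c2)n1` carries a 2-methoxyphenyl, and compound 3 gives 12.3%. The two cores of compound 1 and compound 3 differ by 2-methoxyphenyl in place of 4-methoxyphenyl on an aromatic carbon, which brought a number 70.9 percentage points lower from compound 1 to compound 3 (beyond the scatter). Between the other pair there is a number 1.1 percentage points higher from compound 2 to compound 3 (within the scatter).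

The change from compound 1 to compound 2 is fluoro in place of methoxy on an aromatic carbon, and it gave a number 72 percentage points lower from compound 1 to compound 2 (beyond the scatter). Compound 4 `Fc1ccccc1-c1cn2ccnc2c(-c2ccc3ncn(C4CCCCC4)c3c2)n1` is not yet measured; it differs from compound 3 by fluoro in place of methoxy on an aromatic carbon. This is the same kind of change, but the place differs: in compound 1 the methoxy sits para to a large group, in compound 3 ortho to a large group. Compound 3 gives 12.3%, so little room remains for a drop of the earlier size. For compound 4 a step of a number 2.3 percentage points lower from compound 3 to compound 4 (within the scatter) is expected in this assay. Compound 4 is expected to give 10%, between 0% and 30%.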

Compound 4, a percentage reported as inhibition, at one concentration (the size of the read-out at that concentration, not a potency): 2.94%
The estimate for compound 4 lay 7.1 percentage points above the measured number, within the range that was stated.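

In this assay, fluoro in place of methoxy does not carry over from one core to the other with a similar step: the same change on two cores in this assay, a number 72 percentage points lower (beyond the scatter) from compound 1 to compound 2 and a number 9.4 percentage points lower (within the scatter) from compound 3 to compound 4, 62.6 percentage points apart, beyond the scatter of two such steps

The new compound adds a number 9.4 percentage points lower from compound 3 to compound 4 (within the scatter) and a number 8.3 percentage points lower from compound 2 to compound 4 (within the scatter), against a number 80.3 percentage points lower from compound 1 to compound 4 (beyond the scatter), so among these four compounds the high number belongs to compound 1 alone. This does not show that the place of the group sets the size of the step: compound 3 starts at 12.3%, which leaves little room for a drop of the earlier size, and two pairs make no rule for the series.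

Open, as far as these compounds go, is whether any group other than methoxy on the phenyl arm of compound 1 keeps the high number, for example an amine, a carboxylic acid or a longer chain such as ethoxy. Also open, from the compounds shown here alone, is how the number of compound 1 at one concentration relates to potency.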